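Removing the phenyl group from compound 2

The compounds below may be only part of what the source reports. "The series", "measured", "known", "first", "only" and "open" are said of these compounds alone.

Compound 1 `CCc1noc(CC)c1[C@@H]1C[C@@](C)(c2ccc(F)cc2F)N=C(N)S1`: 35%
Compound 2 `Cc1noc(-c2ccccc2)c1[C@@H]1C[C@@](C)(c2ccc(F)cc2F)N=C(N)S1`: 39%

Both compounds were tested in an ADME assay on microsomes from liver (Homo sapiens) for metabolic stability, with a stated time of 10 min, tested at 0.5 uM; a higher number here means that more of the compound is left, a lower number that less of the compound is left. Within the data shown here, there, compound 2 gives 39%, and this value lies within the usual scatter of the one for compound 1, 35%. The two compounds share a core but differ at more than one place on their five-membered aromatic ring, so no single change can be read from this pair.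

The next compound is compound 3 `Cc1nocc1[C@@H]1C[C@@](C)(c2ccc(F)cc2F)N=C(N)S1`. It is reached from compound 2 by one change, hydrogen in place of phenyl on an aromatic carbon, next to the ring oxygen. Its result in this assay is not yet known.

Among the measured compounds shown here, the measured pair offers no direct step to guide an expectation, so any forecast remains tentative. A moderate rise is expected, with the estimated change being a number 16 percentage points higher from compound 2 to compound 3 (beyond the scatter), and the uncertainty is wide. For compound 3 the estimated value is 55%, with an expected range from 35% to 78%.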

Compound 3, percent of the compound remaining: 65%
The estimate for compound 3 lay 10 percentage points below the measured number, and the stated range covers the measured number.
By their numbers in this assay, from the lowest: compounds 1 and 2 (each within the scatter of the next); then compound 3.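

Among these compounds, the step is a number 26 percentage points higher from compound 2 to compound 3 (beyond the scatter) in this assay, and it is the first single change that can be read, since compounds 1 and 2 differ at more than one place on their five-membered aromatic ring and no step between them can be read. It shows that the group on the aromatic carbon next to the ring oxygen matters for this read-out: with hydrogen in place of phenyl, and so without that six-membered aromatic ring of carbon only, more of the compound is left. Nothing available here bears on why the number rises, so the result stands as an observation without an explanation.

At this position the compounds shown compare only phenyl with hydrogen, so they leave open whether a small group such as a methyl, a methoxy or an amine would keep compound 3 at 65% or bring the number back down. They also leave open how the methyl group on the other ring carbon contributes, as it stays the same across this step.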